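The compounds below may be only part of what the source reports. "The series", "measured", "known", "first", "only" and "open" are said of these compounds alone.

Series notes. Compound 1 `N#Cc1ccc(Nc2nc(Oc3ccnc4ccccc34)nc(N3CCN(C(c4ccccc4)c4ccc(Cl)cc4)CC3)n2)cc1C(F)(F)F` serves as the reference point. In a functional assay on DU-145 cells (Homo sapiens) for cytotoxicity, read by sulforhodamine B assay, with a stated time of 48 h (a higher number here means that more compound is tolerated, a lower number that less compound is tolerated), compound 1 gives > 100000 nM, which is a limit of the assay and not a number. Compound 2 `N#Cc1ccc(Nc2nc(Oc3ccnc4ccccc34)nc(N3CCC(Cc4ccccc4)CC3)n2)cc1C(F)(F)F` is a second measured member. In this assay compound 2 gives > 100000 nM, again a limit. Compound 3 `COc1ccc(N2CCN(c3nc(Nc4ccc(C#N)c(C(F)(F)F)c4)nc(Oc4ccnc5ccccc45)n3)CC2)cc1` is a third. In this assay compound 3 gives > 100000 nM, also a limit. Among the measured compounds shown here, compound 1 thus stands where the other two measured members stand: the limit of > 100000 nM in this assay, at which 3 of the 3 values shown sit, so no measured member has yielded a number, and no step between measured compounds can be sized.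

The next member is compound 4 `N#Cc1ccc(Nc2nc(Oc3ccnc4ccccc34)nc(N3CCN(C(c4ccccc4)c4ccccc4)CC3)n2)cc1C(F)(F)F`. It differs from compound 1 by hydrogen in place of chloro on an aromatic carbon, para to a large group. Nothing measured in the series gives a scale for this change, since every value shown sits at the limit. The working expectation is a step of a number no higher from compound 1 to compound 4 (the limit leaves the size open), none beyond the scatter. Compound 4 is therefore expected to give 100000 nM in this assay, within a range from 30000 nM to 300000 nM, and most probably to be reported once more only as a limit rather than a number.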

Compound 4, concentration lethal to 50% of the cells: > 100000 nM
Compound 4: only a limit was reported; the forecaster's own chance of this, stated with the estimate: 85%; the middle value sits exactly at the limit.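

No new step can be read from compound 1 to compound 4, as both are reported in this assay only as limits and not as numbers: the limit of > 100000 nM in this assay, at which 4 of the 4 values shown sit. The compounds shown leave open where any member's true value lies in this assay, and whether going from 4-chlorophenyl to phenyl changes it at all.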